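The source may report more compounds than this note shows. Statements on the series, on what has been measured and on what is new or still open speak of the compounds shown alone.

Measured so far:
Compound 1, `Cc1cc(Nc2cc(-c3ccccc3)[nH]n2)n2nc(SCc3c(Cl)cccc3Cl)nc2n1`, gives 3230 nM in a functional assay on MCF7 cells (Homo sapiens) for inhibition, read by MTT assay, with a stated time of 72 h; on this read-out lower numbers stand for stronger inhibition and higher numbers for weaker inhibition.
Compound 2, `Cc1cc(Nc2cc(-c3ccc(F)cc3)[nH]n2)n2nc(SCc3ccc(Br)cc3)nc2n1`, gives 4570 nM in this assay.

For the measured compounds named here, these are the only two measured compounds, and compound 1 and compound 2 give numbers that lie within the scatter of each other, so neither can be set ahead of the other in this assay. Going by the values given here, no pair of measured compounds differs in a single place, so nothing measured here shows what any one change does.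

Compound 3, `Cc1cc(Nc2cc(-c3ccccc3)[nH]n2)n2nc(SCC3CC3)nc2n1`, has not yet been tested in this assay. It differs from compound 1 in one place: cyclopropyl in place of 2,6-dichlorophenyl on a saturated chain carbon bound to a sulfur. Among the compounds with values here, no measured pair speaks to this change. Because compound 1 gives 3230 nM, the expectation for compound 3 rests on compound 1 alone. A modest step beyond the scatter toward a higher number, that is toward weaker inhibition, is expected, a 2.5-fold higher number from compound 1 to compound 3 (0.39 log units; beyond the scatter). For compound 3 the estimate in this assay is 8000 nM, with a range from 2500 nM to 25000 nM.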

Compound 3, half-maximal inhibitory concentration: > 50000 nM
Compound 3: only a limit was reported; the forecaster's own chance of this, stated with the estimate: 15%; middle value at least 6.2-fold (0.79 log units) away from the limit.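

Compound 3 gives > 50000 nM in this assay, and this value is a limit of the assay, not a number. Cyclopropyl in place of 2,6-dichlorophenyl on a saturated chain carbon bound to a sulfur gives an at least 15-fold higher number from compound 1 to compound 3 (1.18 log units; beyond the scatter), which is large and is the only step shown that differs in one place, so the earlier compounds could say nothing of this kind. It shows that the group at this place is not interchangeable in this assay, and the full size of the step remains unknown because the value behind it is a limit: the limit of > 50000 nM in this assay, at which 1 of the 3 values shown sits.

This one step replaces an aromatic ring bearing two chlorine atoms with a three-membered ring, and the compounds shown do not tell whether the aromatic ring or the chlorine atoms account for the difference. Nor do they tell how a plain benzyl group, or a longer chain such as n-butyl, would stand at this place in this assay.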